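Trading the Nitrophenyl for a Fluorophenyl on the Ring Nitrogen

The compounds below may be only part of what the source reports. "The series", "measured", "known", "first", "only" and "open" are said of these compounds alone.

Going by the values given here, compound 2 `CC#CC(CC(=O)O)c1ccc(OCc2ccc(C(=O)N3CCN(c4ccc([N+](=O)[O-])cc4)CC3)s2)cc1` holds the only real number among the values shown: in a functional assay on HEK293 cells for agonist activity at Free fatty acid receptor 1 (Homo sapiens), read by fluorescence and calcium flux (a lower number here means that less compound is needed, a higher number that more compound is needed for the effect), compound 2 gives 231 nM. Compound 1 `CC#CC(CC(=O)O)c1ccc(OCc2ccc(C(=O)N3CCN(c4ccncc4)CC3)s2)cc1` reaches only a limit of the assay in this assay, > 5000 nM. Among the compounds with values here, the single measured step, an at least 21-fold lower number from compound 1 to compound 2 (1.33 log units; beyond the scatter), is large and runs from the limit of > 5000 nM in this assay, at which 1 of the 2 values shown sits, to a measured value. Compound 3 `CC#CC(CC(=O)O)c1ccc(OCc2ccc(C(=O)N3CCN(c4ccccc4F)CC3)s2)cc1` differs from compound 2 by 2-fluorophenyl in place of 4-nitrophenyl on an amine nitrogen in a ring. That measured step favoured the 4-nitrophenyl, so removing it is expected to cost potency, though not necessarily back to the limit. Compound 3 is therefore estimated at 1200 nM, between 300 nM and 5000 nM, an expected step of a 5.2-fold higher number from compound 2 to compound 3 (0.72 log units; beyond the scatter).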

Compound 3, half-maximal effective concentration: 113 nM
Estimate against measurement, compound 3: 11-fold (1.03 log units) above, and the stated range ends above it.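

The 4-nitrophenyl is not required for activity in this assay: 2-fluorophenyl, which carries no hydrogen-bond acceptors, gives a 2.0-fold lower number from compound 2 to compound 3 (0.31 log units; beyond the scatter). Two different substituted phenyl groups on this ring nitrogen now outdo pyridin-4-yl, so the gain does not rest on the nitro group alone, with an at least 44-fold lower number from compound 1 to compound 3 (1.64 log units; beyond the scatter). That step gives only a minimum size, because compound 1 stands at a limit of the assay: the limit of > 5000 nM in this assay, at which 1 of the 3 values shown sits.

Going by these compounds, how unsubstituted phenyl, 4-fluorophenyl or 2-methoxyphenyl would compare at this ring nitrogen remains open. So does whether the fluorine itself contributes to the potency of compound 3.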